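Benzyl variation on a triazolopyrimidine hydrazone series

This account rests on a few compounds, and the source may have more. Where it says the series, first, only, none or still open, it means among the compounds named here.

Measured compounds in a functional assay on MGC-803 cells (Homo sapiens) for antiproliferative activity, read by MTT assay, with a stated time of 72 h; a higher number here means a weaker inhibitor, a lower number a stronger inhibitor:
- compound 1, `C#CCSc1nc(N/N=C/c2ccc(N(C)C)cc2)c2nnn(Cc3ccccc3)c2n1`, gives 7620 nM
- compound 2, `CCCSc1nc(N/N=C(\C)c2ccccc2O)c2nnn(Cc3ccccc3Cl)c2n1`, gives 35000 nM
- compound 3, `C#CCSc1nc(N/N=C/c2cc(OC)c(OC)c(OC)c2)c2nnn(Cc3ccccc3)c2n1`, gives 4670 nM

Compound 2 carries the highest number of the three in this assay; its gaps to compound 1 and to compound 3 both lie beyond the usual scatter, so it is the weakest of the set. Compound 2 also differs from the other two at several places at once, so nothing here isolates the effect of the group on the saturated chain carbon bound to an aromatic nitrogen.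

Compound 4, `CCCSc1nc(N/N=C(\C)c2ccccc2O)c2nnn(Cc3ccc(Br)cc3)c2n1`, is not yet measured. It differs from compound 2 only as follows: 4-bromophenyl in place of 2-chlorophenyl on a saturated chain carbon bound to an aromatic nitrogen. Going by the values given here, no measured pair in this set shows this change or any change at that position, so there is no step to lean on. Compound 4 is expected to sit near compound 2, with the step of a 1.4-fold lower number from compound 2 to compound 4 (0.15 log units; within the scatter) estimated as small, in either direction, and not clearly beyond the scatter. For compound 4 the estimate in this assay is 25000 nM, with a range from 8000 nM to 80000 nM.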

Compound 4, half-maximal inhibitory concentration: 11300 nM
For compound 4 the middle estimate is 2.2-fold (0.34 log units) above the measured one; low and high end bracket the measured number.
By their numbers in this assay, from the lowest: compounds 3, 1 and 4 (each within the scatter of the next, the first and the last beyond it); then compound 2.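

In this assay, going by these compounds alone, 2-chlorobenzyl to 4-bromobenzyl gives a 3.1-fold lower number from compound 2 to compound 4 (0.49 log units; beyond the scatter), the first step in the set at the saturated chain carbon bound to an aromatic nitrogen. With the rest of the structure unchanged, this shows that the number responds to the aryl group at this position, though only modestly and only on this one background. No measurement at hand accounts for the step.

The halogen and its place on the ring change together, so the step cannot be assigned to either one alone, and compounds 1 and 3, which carry plain benzyl, differ from compounds 2 and 4 elsewhere as well. Also open, going by these compounds, is how the series would respond to an amine or a carboxylic acid on this benzyl ring.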